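Swapping a Pyridine for a Pyrazine

The compounds below may be only part of what the source reports. "The series", "measured", "known", "first", "only" and "open" are said of these compounds alone.

Compound 1 `c1cncc(-c2ccccc2OCC2=NCCN2)c1` was tested in a functional assay for activation of Alpha-1A adrenergic receptor (Homo sapiens), read by calcium flux (a higher number here means that more compound is needed for the effect, a lower number that less compound is needed), where compound 1 gives 2 nM. Compound 2 `Cc1cccnc1-c1ccccc1OCC1=NCCN1` returns only a limit in this assay, < 100000 nM. So compound 1 carries the only firm number here, the other entry being (the limit of < 100000 nM in this assay, at which 1 of the 2 values shown sits). Compound 3 `c1ccc(-c2cnccn2)c(OCC2=NCCN2)c1` is not yet measured; it differs from compound 1 by pyrazin-2-yl in place of pyridin-3-yl on an aromatic carbon. Going by the values given here, no measured step of this kind exists to lean on, so a modest loss, somewhat beyond the usual scatter, is expected, as the step of a 5.0-fold higher number from compound 1 to compound 3 (0.70 log units; beyond the scatter). Compound 3 is estimated to land near 10 nM, between 2 nM and 100 nM.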

Compound 3, half-maximal effective concentration: 2.51 nM
Estimate against measurement, compound 3: 4.0-fold (0.60 log units) above; the measured number falls inside the stated range.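

In this assay the exchange of pyridin-3-yl for pyrazin-2-yl gives a 1.3-fold higher number from compound 1 to compound 3 (0.10 log units; within the scatter) and so costs nothing that can be told from the usual scatter. This first measured step at this position shows that a ring with 2 hetero atoms and 2 hydrogen-bond acceptors can stand where a ring with 1 of each stood. Nothing shown here explains why the two rings match. From the compounds shown here alone, whether the position would also accept a group that is no aromatic ring, such as an amine or a carboxylic acid, stays open.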